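The source may hold more compounds than are shown below. What is called first, only, known or untested is meant among the compounds shown, and "the series" means these compounds.

Compound 1 `CC(C)C1(C(C)C)NC(=O)N(CN2CCN(c3cccc(C(F)(F)F)c3)CC2)C1=O` was tested in a functional assay on the whole organism (strain CD1) with Mus musculus as the target, in the maximal electroshock model, with a stated time of 4 h (on this read-out lower numbers stand for an effect already at smaller amounts and higher numbers for an effect only at larger amounts of compound), where compound 1 gives 100 mg/kg. Compound 2 `O=C1NC(c2ccccc2)(c2ccccc2)C(=O)N1CN1CCN(c2ccc(F)cc2)CC1` is the only other compound with a result in this assay, and compound 2 gives 100 mg/kg, so the two stand level at the digits shown, within the usual scatter. For the measured compounds named here, no step between measured compounds differing in a single place has been established, and the two measured compounds differ in several places at once, so their values can only be set side by side. Compound 3 `CC(C)C1(C(C)C)NC(=O)N(CN2CCN(c3ccccc3)CC2)C1=O` has not yet been measured in this assay. It differs from compound 1 by hydrogen in place of trifluoromethyl on an aromatic carbon. Going by the values given here, with no single-point step to lean on, the size of this change cannot be read from earlier pairs; a step of no change at the digits printed from compound 1 to compound 3 (within the scatter) is expected, meaning no change beyond the scatter. Compound 3 is therefore estimated at 100 mg/kg in this assay, in the range 50 mg/kg to 200 mg/kg.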

Compound 3, minimum effective dose: 300 mg/kg
Estimate against measurement, compound 3: 3.0-fold (0.48 log units) below; the whole stated range lies below it.
By their numbers in this assay, from the lowest: compounds 1 and 2 (each within the scatter of the next); then compound 3.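

For the compounds shown here, replacing 3-(trifluoromethyl)phenyl with phenyl gives the first single-place step in this assay, with a 3.0-fold higher number from compound 1 to compound 3 (0.48 log units; beyond the scatter). On the shared core, this aromatic carbon is therefore not indifferent to what it carries: with trifluoromethyl there, the effect appears at smaller amounts than with hydrogen. Nothing at hand accounts for the size or direction of this step.

A chlorine atom, a methoxy group or a nitrile on this aromatic carbon would show whether the step belongs to trifluoromethyl specifically or would follow other groups placed there. Going by these compounds, it also remains open whether trifluoromethyl and hydrogen would differ in the same way on the core of compound 2.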